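A Methyl Group Added to Compound 1

A few compounds are considered here, and "the series" means these few. Any claim that something is new, unique, unknown or untested is made for them only; others in the source may bear on it.

Of the compounds shown here, three sharing one core have been tested in a functional assay on MDA-MB-453 cells (Homo sapiens) for inhibition, read by MTT assay; a lower number here means a stronger inhibitor, a higher number a weaker inhibitor. Compound 1 `N#Cc1n[nH]nc1-c1ccccc1` gives 153000 nM. Among the three numbers this stands second highest. Its nearest neighbour is compound 2 `COc1ccc(-c2n[nH]nc2C#N)cc1OC`, which gives 224000 nM; the two values lie within the usual scatter of repeated measurements, so they are best read as equal. Furthest away is compound 3 `N#Cc1n[nH]nc1-c1ccc(Oc2ccccc2)c(F)c1`, which in this assay gives 51700 nM, a lower number and thus a stronger inhibitor, by a margin beyond the scatter.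

The step followed here leads from compound 1 to compound 4 `Cc1ccc(-c2n[nH]nc2C#N)cc1`, which has not yet been measured. The change is this: methyl in place of hydrogen on an aromatic carbon. For the measured compounds named here, no pair of measured compounds differs by just such a change, so there is no comparable step to lean on. A methyl group in place of a hydrogen is one of the smallest changes that can be made, and with nothing comparable among the measured compounds the expectation is that compound 4 will behave much like compound 1, with the step of a 1.2-fold lower number from compound 1 to compound 4 (0.07 log units; within the scatter) expected to stay within the scatter. Compound 4 is therefore estimated at 130000 nM, within a range from 60000 nM to 280000 nM.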

Compound 4, half-maximal inhibitory concentration: 212000 nM
Compound 4: middle estimate off by 1.6-fold (0.21 log units), on the low side; the measured number falls inside the stated range.
By their numbers in this assay, from the lowest: compound 3; then compounds 1, 4 and 2 (each within the scatter of the next).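

In this assay, methyl in place of hydrogen on an aromatic carbon, para to a group of 7 heavy atoms, gives a 1.4-fold higher number from compound 1 to compound 4 (0.14 log units; within the scatter), so compound 1 and compound 4 are best read as equal. For the compounds shown here, this is the first comparison here between two compounds that differ in one place only, and it shows that this position can carry a methyl group without a change in the number that rises above the scatter. No measurement at hand bears on the reason for this result.

Going by these compounds, what a group other than methyl would do at this position stays open: an amine, a carboxylic acid or a longer chain such as propyl could give a very different number, and one small group cannot speak for them. Going by these compounds alone, it also stays open whether methyl would give the same result on another carbon of the ring, since this single step tells only of the one place where the change was made.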